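Piperazine in Place of Dimethylamine on the Ether Chain

The source may report more compounds than this note shows. Statements on the series, on what has been measured and on what is new or still open speak of the compounds shown alone.

Compound 1 `CCN1CCC(COc2ccc(-c3nc4ccc(Oc5ccc(Cl)cc5)cc4o3)cc2)CC1` and compound 2 `CN(C)CCCOc1ccc(-c2nc3ccc(Oc4ccc(Cl)cc4)cc3o2)cc1` were both tested in an assay on isolated protein for inhibition of advanced glycosylation end product-specific receptor (Homo sapiens), read by FRET, with stated times of 30 min and 1 h, tested at 4 uM; a higher number here means more inhibition at the concentration tested (going by the name of the read-out), a lower number less inhibition. Compound 1 gives 2.1%, while compound 2 gives 4.9%, the higher of the two numbers, although a number 2.8 percentage points higher from compound 1 to compound 2 (within the scatter). Compound 3 `Clc1ccc(Oc2ccc3nc(-c4ccc(OCCCN5CCNCC5)cc4)oc3c2)cc1` differs from compound 2 in one place: piperazin-1-yl in place of dimethylamino on a saturated chain carbon, three bonds along the chain from an oxygen on an aromatic ring. For the measured compounds named here, the only measured step also changed the group on the saturated chain carbon bound to an oxygen on an aromatic ring and stayed within the scatter, so compound 3 is expected to show no step beyond the scatter, a number 0.1 percentage points higher from compound 2 to compound 3 (within the scatter). Compound 3 is estimated at 5%, between -5% and 15%.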

Compound 3, a percentage reported as inhibition, at one concentration (the size of the read-out at that concentration, not a potency): 42.7%
Compound 3: middle estimate off by 37.7 percentage points, on the low side; the whole stated range lies below it.
By their numbers in this assay, from the lowest: compounds 1 and 2 (each within the scatter of the next); then compound 3.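

In this assay, this place on the chain proved sensitive to the group it carries: piperazin-1-yl in place of dimethylamino gives a number 37.8 percentage points higher from compound 2 to compound 3 (beyond the scatter). The same ring also separates from the other amine, with 2-(piperazin-1-yl)ethyl in place of 1-ethylpiperidin-4-yl giving a number 40.6 percentage points higher from compound 1 to compound 3 (beyond the scatter). Nothing available bears on what lies behind these steps. Going by these compounds, whether the gain needs the six-membered ring, its second nitrogen or its hydrogen-bond donor remains open; 4-methylpiperazin-1-yl or morpholin-4-yl at this place would separate these. On these data alone, how a shorter or longer chain carrying piperazin-1-yl would read also remains open.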